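The source may hold more compounds than are shown below. What is called first, only, known or untested is meant among the compounds shown, and "the series" means these compounds.

Of the compounds shown here, three have been tested so far in a functional assay on SW982 cells (Homo sapiens) for inhibition, read by scintillation counting; a higher number here means a weaker inhibitor, a lower number a stronger inhibitor. Among the measured compounds shown here, compound 1 `CCCCCCCCc1ccc(OCC(=O)c2nc(CC(=O)OCC)cs2)cc1` gives 5000 nM, the only actual number among them. Compound 2 `CCCCCCCCCCCCOCC(=O)c1nc(C(=O)OCC)cs1` is reported as "not active" (no number reported). Compound 3 `O=C(COc1ccccc1)c1nccs1` is also reported as "not active" (no number reported), so it has no single number and offers only a qualitative starting point.

Compound 4 `O=C(COc1ccc(-c2ccccc2)cc1)c1nccs1` comes from compound 3 through one structural change, (phenyl in place of hydrogen on an aromatic carbon). This places phenyl in place of hydrogen on an aromatic carbon. For the measured compounds named here, no measured pair shows what this change does on its own. The nearest guide is compound 1, which also carries a larger group on its aromatic ring, though it differs from compound 3 in more than one place, and compound 1 gives 5000 nM. Size alone is a poor guide, since compound 2, with its long chain, gives "not active" (no number reported).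

The expected step is a modest one, from no measurable inhibition to weak inhibition at best, and compound 4 may also come back without a number. For compound 4, the estimated value is 8000 nM, with an expected range of 2000 nM to 30000 nM.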

Compound 4, half-maximal inhibitory concentration: 2800 nM
Beside the measured number, compound 4's estimate is 2.9-fold (0.46 log units) above it, within the range that was stated.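

Compound 3 is reported as "not active" with no number, so no step can be read between it and compound 4 (2800 nM). Nothing measured here explains the result. From the compounds shown here alone, how much the phenyl group alone changes inhibition remains open.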